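Swapping an Aryl End for Furan in a Growth Assay

The compounds below may be only part of what the source reports. "The series", "measured", "known", "first", "only" and "open" are said of these compounds alone.

In a functional assay on HCT-116 cells (Homo sapiens) for inhibition, read by sulforhodamine B assay, with a stated time of 48 h, tested at 50 uM (a higher number here means more inhibition of growth at the concentration tested, a lower number less inhibition of growth), compound 1 (`COc1cccc(/C=C/C(=O)/C=C/c2ccc(OCc3cn(CCCCCOc4cc(=O)oc5ccccc45)nn3)c(OC)c2)c1`) gives 36%. Compound 2 (`COc1cc(/C=C/C(=O)/C=C/c2ccccc2)ccc1OCc1cn(CCCCOc2cc(=O)oc3ccccc23)nn1`) gives 34%, which lies within the scatter of that result, so the two stand level. Compound 3 (`COc1ccc(/C=C/C(=O)/C=C/c2ccc(OCc3cn(CCOc4cc(=O)oc5ccccc45)nn3)c(OC)c2)cc1OC`) gives 82%, a result beyond the scatter from compound 1. Among the measured compounds shown here, these three compounds differ in more than one place, so no measured step isolates any single change.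

Compound 4 (`COc1cc(/C=C/C(=O)/C=C/c2ccco2)ccc1OCc1cn(CCCCCOc2cc(=O)oc3ccccc23)nn1`) keeps the rest of compound 1 and carries furan-2-yl in place of 3-methoxyphenyl on a double-bonded chain carbon bound to a double-bonded chain carbon. For the measured compounds named here, no measured pair shows what this swap does in this assay, so no step beyond the scatter is expected, in either direction. The expected step, a number 2 percentage points higher from compound 1 to compound 4 (within the scatter), stays within the scatter. The expectation starts from compound 1 at 36%, and the range is kept wider on the upper side because compound 3 at 82% shows how high values in this small set can go. For compound 4 the estimated value is 38%, with an expected range from 20% to 62%.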

Compound 4, percent growth inhibition at one concentration: 37%
Beside the measured number, compound 4's estimate is 1 percentage points above it; the measured number falls inside the stated range.
By their numbers in this assay, from the lowest: compounds 2, 1 and 4 (each within the scatter of the next); then compound 3.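

In this assay, among the compounds shown here, the step of a number 1 percentage points higher from compound 1 to compound 4 (within the scatter) is the first measured step in this set to isolate a single change, and it lies within the scatter. On a double-bonded chain carbon bound to a double-bonded chain carbon, furan-2-yl therefore stands level with 3-methoxyphenyl in this pair, even though the entering group has 5 heavy atoms and one five-membered aromatic ring with 1 hetero atom, while the leaving group has 8 heavy atoms and one six-membered aromatic ring of carbon only. Nothing shown here offers an explanation for this level result.

The compounds shown leave open whether a group of another kind at this place, such as a phenyl ring carrying a carboxylic acid or a dimethylamino group, would also stay level with compound 1. For the compounds shown here, they also leave open which of the several differences from compound 1 goes with the higher value of compound 3 at 82%, and whether furan-2-yl would stay level with 3-methoxyphenyl on a shorter chain like the one in compound 3.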